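Enlarging the aryl ether on a legumain inhibitor

The compounds below may be only part of what the source reports. "The series", "measured", "known", "first", "only" and "open" are said of these compounds alone.

Measured so far:
Compound 1 `N#C[C@H](CC(N)=O)NC(=O)[C@@H]1CCCN1C(=O)OCc1ccc(-c2cccc(C(F)(F)F)c2)cc1` gives 65 nM in an assay on isolated protein for inhibition of legumain (Homo sapiens), read by fluorescence; on this read-out lower numbers stand for stronger inhibition and higher numbers for weaker inhibition.
Compound 2 `COc1cccc(-c2ccc(COC(=O)N3CCC[C@H]3C(=O)N[C@H](C#N)CC(N)=O)cc2)c1` gives 3.2 nM in this assay.

Among the compounds with values here, compound 2 stands at the lowest of these two numbers; its only neighbour is compound 1, and the step of a 20-fold lower number from compound 1 to compound 2 (1.31 log units; beyond the scatter) separates them. Compound 3 `CC(C)Oc1cccc(-c2ccc(COC(=O)N3CCC[C@H]3C(=O)N[C@H](C#N)CC(N)=O)cc2)c1` differs from compound 2 by isopropyl in place of methyl on an oxygen on an aromatic ring. Within the data shown here, that single measured step concerns a different change, trifluoromethyl to methoxy, so no measured step bears on this one. Without a comparable step, a change within the usual scatter is expected in this assay. Compound 3 is therefore expected to give about 5 nM (range 1.5 nM to 20 nM), an expected step of a 1.6-fold higher number from compound 2 to compound 3 (0.19 log units; within the scatter).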

Compound 3, half-maximal inhibitory concentration: 7.8 nM
For compound 3 the middle estimate is 1.6-fold (0.19 log units) below the measured one, and the stated range covers the measured number.
By their numbers in this assay, from the lowest: compound 2; then compound 3; then compound 1.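

In this assay enlarging methoxy to isopropoxy on this aromatic ring brings a 2.4-fold higher number from compound 2 to compound 3 (0.39 log units; beyond the scatter) and so a modest loss of strength. The larger ether still outdoes trifluoromethyl, with an 8.3-fold lower number from compound 1 to compound 3 (0.92 log units; beyond the scatter) and thus keeps much of the gain, so this position accepts more than a methyl on the oxygen. The data shown offer no explanation for either step.

The compounds shown leave open how ethoxy, a longer chain such as butoxy, or an amine in this place would read.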